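Thiophene to naphthalene on the hydrazone of compound 1

The compounds below may be only part of what the source reports. "The series", "measured", "known", "first", "only" and "open" are said of these compounds alone.

Compound 1 `CCCSc1nc(N/N=C/c2cccs2)c2nnn(Cc3ccccc3)c2n1` is the starting point. In a functional assay on MCF7 cells (Homo sapiens) for antiproliferative activity, read by MTT assay, with a stated time of 72 h (a higher number here means a weaker inhibitor, a lower number a stronger inhibitor), compound 1 gives only a limit, > 64000 nM, not a measured number (the limit of > 64000 nM in this assay, at which 1 of the 3 values shown sits). Two related compounds carry a six-membered carbon ring in place of the five-membered sulfur ring: compound 2 `CCCSc1nc(N/N=C(\C)c2ccccc2O)c2nnn(Cc3ccccc3)c2n1` gives 11000 nM in this assay, and compound 3 `CCCSc1nc(N/N=C(\C)c2ccc(Br)cc2)c2nnn(Cc3ccccc3)c2n1` gives 13000 nM. The step of an at least 5.8-fold lower number from compound 1 to compound 2 (0.76 log units; beyond the scatter) and the step of an at least 4.9-fold lower number from compound 1 to compound 3 (0.69 log units; beyond the scatter) both point the same way, while the step of a 1.2-fold higher number from compound 2 to compound 3 (0.07 log units; within the scatter) is small. Compound 4 `CCCSc1nc(N/N=C/c2ccc3ccccc3c2)c2nnn(Cc3ccccc3)c2n1` changes the same part of the molecule: naphthalen-2-yl in place of thiophen-2-yl on a carbon with a double bond to nitrogen. Because the steps of an at least 5.8-fold lower number from compound 1 to compound 2 (0.76 log units; beyond the scatter) and an at least 4.9-fold lower number from compound 1 to compound 3 (0.69 log units; beyond the scatter) show that moving away from the thiophene lowers the number, a lower number is expected for compound 4 as well, though those two steps also changed the carbon bearing the double bond, which compound 4 does not. The expected step is an at least 3.2-fold lower number from compound 1 to compound 4 (0.50 log units; beyond the scatter). For compound 4 the estimate in this assay is 20000 nM, with a range from 7000 nM to 64000 nM.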

Compound 4, half-maximal inhibitory concentration: > 64000 nM
Compound 4: no number, only a limit; the forecaster's own chance of this, stated with the estimate: 35%; at least 3.2-fold (0.50 log units) between middle value and limit.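

Compound 1 and compound 4 each give only a limit of the assay, not a number, so the step from one to the other cannot be read: the limit of > 64000 nM in this assay, at which 2 of the 4 values shown sit.

The compounds shown leave open how naphthalen-2-yl and thiophen-2-yl truly compare in this assay.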